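Extending an ortho substituent on a cyclic ketone series

A few compounds are considered here, and "the series" means these few. Any claim that something is new, unique, unknown or untested is made for them only; others in the source may bear on it.

Among the compounds with values here, compound 2 `CCc1ccccc1CC1CCc2cc(OC)ccc2C1=O` gives the lower of the two numbers measured so far in an assay on CHO cells for inhibition of 1,25-dihydroxyvitamin D(3) 24-hydroxylase, mitochondrial (Homo sapiens) (a higher number here means a weaker inhibitor, a lower number a stronger inhibitor), at 1920 nM, while compound 1 `COc1ccc2c(c1)CC/C(=C\c1ccccc1C(F)(F)F)C2=O` gives 11200 nM in this assay, a gap that lies beyond the scatter. Compound 3 `COc1ccc2c(c1)CCC(Cc1ccccc1/C=C/c1ccccc1)C2=O` has not yet been measured; it differs from compound 2 by 2-phenylethenyl in place of ethyl on an aromatic carbon, at a position ortho to a large group. Within the data shown here, with no measured step of this kind available, the step of a 1.2-fold lower number from compound 2 to compound 3 (0.08 log units; within the scatter) is expected to stay close to the scatter, in either direction. Compound 3 is therefore estimated at 1600 nM in this assay, within 400 nM to 6500 nM.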

Compound 3, half-maximal inhibitory concentration: 343000 nM
Beside the measured number, compound 3's estimate is 210-fold (2.33 log units) below it; the whole stated range lies below it.
By their numbers in this assay, from the lowest: compound 2; then compound 1; then compound 3.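

At this aromatic carbon, ortho to a large group, the position proves far from indifferent to what it carries: in this assay, exchanging ethyl for 2-phenylethenyl gives a 180-fold higher number from compound 2 to compound 3 (2.25 log units; beyond the scatter). Within the data shown here, this is the first step measured at this position, and it shows that the larger group, which brings an aromatic ring and a double bond, is poorly accepted there. Nothing measured here explains the loss. The compounds shown leave open whether the added ring or the double bond accounts for it. A 2-phenylethyl group or a propyl chain at this carbon would separate the two.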